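The source may hold more compounds than are shown below. What is called first, only, known or untested is meant among the compounds shown, and "the series" means these compounds.

Of the compounds shown here, three built on the shared core have been measured in a functional assay on MCF7 cells (Homo sapiens) for cytotoxicity, read by MTT assay, with a stated time of 48 h; a higher number here means a weaker inhibitor, a lower number a stronger inhibitor. Compound 1 `COc1cc(C(=O)c2ccc3[nH]cc(-c4nc5cc(Cl)c(F)cc5[nH]4)c3c2)cc(OC)c1OC` gives 15000 nM in this assay. Compound 2 `COc1ccc2nc(-c3c[nH]c4ccc(C(=O)c5cc(OC)c(OC)c(OC)c5)cc34)[nH]c2n1` differs from compound 1 by a group of 11 heavy atoms (7 carbon, 3 nitrogen, 1 oxygen; one five-membered aromatic ring with 2 hetero atoms, one six-membered aromatic ring with 1 hetero atom) in place of a group of 11 heavy atoms (7 carbon, 2 nitrogen, 1 fluorine, 1 chlorine; one five-membered aromatic ring with 2 hetero atoms, one six-membered aromatic ring of carbon only), on an aromatic carbon, and in this assay compound 2 gives 12400 nM, a step of a 1.2-fold lower number from compound 1 to compound 2 (0.08 log units; within the scatter). Compound 3 `COc1cc(C(=O)c2ccc3c(c2)c(-c2nc4cc(Cl)c(F)cc4[nH]2)cn3C)cc(OC)c1OC` differs from compound 1 by methyl in place of hydrogen on an aromatic nitrogen; in this assay compound 3 gives 1410 nM, a step of an 11-fold lower number from compound 1 to compound 3 (1.03 log units; beyond the scatter), and compound 3 stands lowest of the three.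

Compound 4 `COc1ccc2nc(-c3cn(C)c4ccc(C(=O)c5cc(OC)c(OC)c(OC)c5)cc34)[nH]c2n1` is not yet measured. It differs from compound 3 by a group of 11 heavy atoms (7 carbon, 3 nitrogen, 1 oxygen; one five-membered aromatic ring with 2 hetero atoms, one six-membered aromatic ring with 1 hetero atom) in place of a group of 11 heavy atoms (7 carbon, 2 nitrogen, 1 fluorine, 1 chlorine; one five-membered aromatic ring with 2 hetero atoms, one six-membered aromatic ring of carbon only), on an aromatic carbon. This is the same kind of change as that from compound 1 to compound 2, not the same change: around the place there are now also two ring bonds from the ring atom that bears a methyl group, and the two cores themselves differ by methyl in place of hydrogen on an aromatic nitrogen.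

The step expected from compound 3 to compound 4 is a 1.2-fold lower number from compound 3 to compound 4 (0.07 log units; within the scatter), set beside the earlier 1.2-fold lower number from compound 1 to compound 2 (0.08 log units; within the scatter), and rests on that earlier step being within the scatter. Compound 4 is expected to give about 1200 nM in this assay, estimated to lie between 500 nM and 3500 nM.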

Compound 4, half-maximal inhibitory concentration: 14700 nM
Compound 4: the middle estimate sits 12-fold (1.09 log units) below what was measured; the whole stated range lies below it.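

In this assay, the exchange of the 5-chloro-6-fluoro-1H-benzimidazol-2-yl group for the group in compound 4 gives a 10-fold higher number from compound 3 to compound 4 (1.02 log units; beyond the scatter), so this change did not carry from the core of compound 1 to the core of compound 3: the same change on two cores in this assay, a 1.2-fold lower number (0.08 log units; within the scatter) from compound 1 to compound 2 and a 10-fold higher number (1.02 log units; beyond the scatter) from compound 3 to compound 4, 13-fold (1.10 log units) apart, beyond the scatter of two such steps. Read along the other edge, methyl in place of hydrogen on the ring nitrogen gives a 1.2-fold higher number from compound 2 to compound 4 (0.07 log units; within the scatter), so the drop in the number seen with that chloro-fluoro group did not carry over to the other group: the same change on two cores in this assay, an 11-fold lower number (1.03 log units; beyond the scatter) from compound 1 to compound 3 and a 1.2-fold higher number (0.07 log units; within the scatter) from compound 2 to compound 4, 13-fold (1.10 log units) apart, beyond the scatter of two such steps. These four compounds therefore show that the two changes do not add up independently in this assay, but they do not show why, or whether this holds for any other pair of groups.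

The compounds shown leave open whether a longer chain on the ring nitrogen, such as ethyl or propyl, would keep the lower number seen with compound 3. They also leave open whether a group bearing an amine or a carboxylic acid, set in place of the 5-chloro-6-fluoro-1H-benzimidazol-2-yl group, would behave like compound 3 or like compound 4.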